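The source may hold more compounds than are shown below. What is called first, only, known or untested is meant among the compounds shown, and "the series" means these compounds.

Compound 1 `CCOC(=O)CCCCCOc1cccc(CN(C(=O)c2ccc(-c3cccnc3)cc2)C(C)C)c1` gave > 26000 nM in an ADME assay on BJ cells (Homo sapiens) for cytotoxicity, read by CellTiter-Glo and resazurin assay, with a stated time of 72 h; a lower number here means that less compound is needed, a higher number that more compound is needed for the effect; this value is a limit of the assay, not a number.
Compound 2 `CCOC(=O)CCCCCOc1cccc(CN(C(=O)c2ccc(-c3cccc(OC)c3)cc2)C(C)C)c1` gave > 21000 nM in this assay; this too is a limit of the assay.

Within the data shown here, the single step that connects the two measured compounds, a step that the two limits leave unreadable from compound 1 to compound 2, cannot be read, since both of its ends sit at a limit. Compound 2 therefore stands at one of the two limits shown, (the limit of > 21000 nM in this assay, at which 1 of the 2 values shown sits), and the only other value shown is itself a limit, (the limit of > 26000 nM in this assay, at which 1 of the 2 values shown sits), so neither compound can be placed relative to the other.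

Compound 3 `CCOC(=O)CCCCCOc1cccc(CN(C(=O)c2ccc(-c3cc(F)cc(OC)c3)cc2)C(C)C)c1` differs from compound 2 by fluoro in place of hydrogen on an aromatic carbon. No measured step bears on this change, and the one step shown gives no readable size, so no direction can be drawn from it. The expectation is simply that compound 3 will behave like compound 2 and again return a limit in this assay, with a step that the limit leaves unreadable from compound 2 to compound 3 expected. Compound 3 is estimated at 30000 nM, within a range from 8000 nM to 100000 nM.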

Compound 3, half-maximal effective concentration: > 26000 nM
Compound 3 ended at the assay's limit; the forecaster's own chance of this, stated with the estimate: 80%; the middle value does not contradict the limit.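

Compound 3 gave > 26000 nM in this assay, and this value is a limit of the assay. Neither the step between compound 2 and compound 3 nor the step between compound 1 and compound 3 can be read. The compounds shown leave open where compound 1, compound 2 and compound 3 would each reach the half-maximal effect, and whether fluoro in place of hydrogen alters it.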